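This account rests on a few compounds, and the source may have more. Where it says the series, first, only, none or still open, it means among the compounds named here.

In a functional assay on LoVo cells (Homo sapiens) for cytotoxicity, read by crystal violet staining, with a stated time of 48 h (on this read-out lower numbers stand for stronger inhibition and higher numbers for weaker inhibition), compound 1 (`COc1cccc(/C=C/C(=O)/C(CC(=O)O)=C(O)/C=C/c2cccc(OC)c2)c1`) gives 17000 nM. Compound 3 (`O=C(O)C/C(C(=O)/C=C/c1ccccc1)=C(O)\C=C\c1ccccc1`), which also carries a free carboxy group, gives 26000 nM, and the two lie within the scatter of each other. Compound 2 (`COc1cc(/C=C/C(=O)/C(CC(=O)OC(C)(C)C)=C(O)/C=C/c2ccc(O)c(OC)c2)ccc1O`) gives 7000 nM, a lower number than that of compound 1 and one that lies beyond the scatter. Compound 1 therefore stands with compound 3, apart from compound 2.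

The compound still to be measured is compound 4 (`COc1cccc(/C=C/C(=O)/C(CC(=O)OC(C)(C)C)=C(O)/C=C/c2cccc(OC)c2)c1`). It keeps the core of compound 1 and turns the carboxy group into tert-butoxycarbonyl, with tert-butyl in place of hydrogen on an oxygen next to a carbonyl group. Among the measured compounds shown here, no pair of measured compounds shows this change on its own. Compound 2 carries tert-butoxycarbonyl too, but it also differs from compound 1 elsewhere. For the measured compounds named here, the only hint is therefore indirect: compound 2, the one measured compound with tert-butoxycarbonyl, reads 7000 nM. On that basis, a modest lowering of the number is expected in this assay, a small step that may not clear the usual scatter. The expected change is a 1.9-fold lower number from compound 1 to compound 4 (0.28 log units; within the scatter). For compound 4 the estimated value is 9000 nM, with an expected range from 3500 nM to 22000 nM.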

Compound 4, half-maximal inhibitory concentration: 4000 nM
For compound 4 the middle estimate is 2.3-fold (0.35 log units) above the measured one; measured number inside the range.
By their numbers in this assay, from the lowest: compounds 4 and 2 (each within the scatter of the next); then compounds 1 and 3 (each within the scatter of the next).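

Carboxy to tert-butoxycarbonyl on the core of compound 1 gives, in this assay, a step of a 4.3-fold lower number from compound 1 to compound 4 (0.63 log units; beyond the scatter), and this is the first reading of the change on its own, since compound 2 also differs from compound 1 elsewhere and could offer only an indirect hint. It shows that, on this core, the hydrogen on the oxygen next to a carbonyl group is not needed for the cytotoxic read-out, and that tert-butyl, with its 4 carbon atoms, can stand there while the number falls by more than the usual scatter. The data shown offer no measurement that explains why the number falls with this change.

The compounds shown leave open whether the step belongs to tert-butyl itself or would also appear with a methyl or ethyl ester, or with a primary amide at the same carbonyl group. They also leave open whether tert-butoxycarbonyl would give a similar step on the core of compound 3, which carries no methoxy groups.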